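Tertiary amine series: carbamoyl replaced by acetylpyrrolidinyl

A few compounds are considered here, and "the series" means these few. Any claim that something is new, unique, unknown or untested is made for them only; others in the source may bear on it.

For compound 1 `CC(C)(C)OC(=O)CN(Cc1ccc(Cl)cc1)Cc1cccs1` the entry in a functional assay on HEK293 cells for agonist activity at nuclear receptor subfamily 1 group D member 1 (Homo sapiens), read by a luciferase reporter, with a stated time of 24 h (on this read-out higher numbers stand for an effect only at larger amounts of compound and lower numbers for an effect already at smaller amounts), is "not determined" (no result reported), so nothing can be said of it on the numbers. Within the data shown here, compound 2 `NC(=O)CN(Cc1ccc(Cl)cc1)Cc1ccc([N+](=O)[O-])s1` is the only compound of the series with a value: in this assay compound 2 gives 3000 nM, and with no second number it cannot be placed relative to anything else.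

Compound 3 `CC(=O)N1CCC(CN(Cc2ccc(Cl)cc2)Cc2ccc([N+](=O)[O-])s2)C1` is the next compound to be measured in this assay. The difference from compound 2 is 1-acetylpyrrolidin-3-yl in place of carbamoyl on a saturated chain carbon bound to an amine nitrogen. Both groups carry one double bond outside aromatic rings and one hydrogen-bond acceptor; the carbamoyl that leaves brings a hydrogen-bond donor, the 1-acetylpyrrolidin-3-yl that enters brings none and adds a five-membered non-aromatic ring.

Among the measured compounds shown here, no step between measured compounds exists to calibrate this change, so the expectation rests on compound 2 alone. The step of a 1.3-fold higher number from compound 2 to compound 3 (0.12 log units; within the scatter) is expected to be small, most likely within the usual scatter, with a lean toward a somewhat larger concentration rather than a smaller one. For compound 3 the estimate in this assay is 4000 nM, with a range from 900 nM to 15000 nM.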

Compound 3, half-maximal effective concentration: 1600 nM
Compound 3: middle estimate off by 2.5-fold (0.40 log units), on the high side; the measured number falls inside the stated range.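

In this assay, among these compounds, 1-acetylpyrrolidin-3-yl in place of carbamoyl on a saturated chain carbon bound to an amine nitrogen gives a 1.9-fold lower number from compound 2 to compound 3 (0.27 log units; within the scatter), so this is the first step that can be read. At this place, the larger group with its five-membered non-aromatic ring is tolerated, and the hydrogen-bond donor of carbamoyl is not needed for a measurable value in this assay, since compound 2 and compound 3 lie within the scatter of each other. No measured property of either compound bears on this result, so the step stands without an explanation.

As far as these compounds go, whether a carboxylic acid, a primary amine or a longer chain ending in carbamoyl on the same carbon would give a step beyond the scatter remains open, as does whether 1-acetylpyrrolidin-3-yl differs from a 1-acetylpiperidin-4-yl group with its six-membered ring. Steps to compound 1 cannot be read, as it has no number, and a single step says nothing about how far the series can move at this place in either direction.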